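Series around a shared core: amide variations and an ester ether

The source may hold more compounds than are shown below. What is called first, only, known or untested is meant among the compounds shown, and "the series" means these compounds.

Three compounds share the core of compound 1 `NC(=O)/C=C/c1ccncc1-c1ccc2ccccc2c1` and differ only in the group on the carbonyl carbon. In an assay on a protein complex for inhibition of CDK8/Cyclin C (Homo sapiens), with a stated time of 1 h, tested at 10 uM (a lower number here means less inhibition, a higher number more inhibition at the concentration tested (going by the name of the read-out)), compound 1 gives 102%; compound 2 `COC1CN(C(=O)/C=C/c2ccncc2-c2ccc3ccccc3c2)C1` gives 100% and compound 3 `CN1CCN(C(=O)/C=C/c2ccncc2-c2ccc3ccccc3c2)CC1` gives 101%. Compound 1 stands highest of the three numbers, yet every step among them lies within the scatter: a number 2 percentage points lower from compound 1 to compound 2 (within the scatter), a number 1 percentage points lower from compound 1 to compound 3 (within the scatter), a number 1 percentage points higher from compound 2 to compound 3 (within the scatter). Within this set, exchanging the amide substituent has no visible effect on inhibition.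

Compound 4 `COC(=O)COc1ccncc1-c1ccc2ccccc2c1` differs from compound 1 in another way: (methoxycarbonyl)methoxy in place of 2-carbamoylethenyl on an aromatic carbon. The whole 2-carbamoylethenyl group leaves and (methoxycarbonyl)methoxy enters on the same aromatic carbon. Among the measured compounds shown here, none of the measured steps bears on this change, since all three vary only the group on the carbonyl carbon while the carbamoylethenyl linker stays in place. The measured steps therefore give no guide to the size or direction of the step in this assay.

For the measured compounds named here, with no step to rest on, and a replacement of the full side chain rather than its terminus, compound 4 is expected to show clearly lower inhibition, estimated at 50% with a range of 5% to 95%. The expected step from compound 1 to compound 4 is a number 52 percentage points lower from compound 1 to compound 4 (beyond the scatter), well beyond the scatter.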

Compound 4, a percentage reported as inhibition, at one concentration (the size of the read-out at that concentration, not a potency): 11%
Estimate against measurement, compound 4: 39 percentage points above; low and high end bracket the measured number.
By their numbers in this assay, from the lowest: compound 4; then compounds 2, 3 and 1 (each within the scatter of the next).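

Among the compounds shown here, earlier changes to the group on the carbonyl carbon left this assay flat, whereas replacing the whole side chain on the aromatic carbon opposite the ring nitrogen gives a number 91 percentage points lower from compound 1 to compound 4 (beyond the scatter) and is the first large step in this set. The read-out at this position therefore depends on more than the terminal amide substituent that varies across compound 1, compound 2 and compound 3. The exchange removes 2-carbamoylethenyl, with 1 hydrogen-bond donor and 2 double bonds outside aromatic rings, and introduces (methoxycarbonyl)methoxy, with 0 hydrogen-bond donors and 1 double bond outside aromatic rings, but no available evidence links the step to any of these differences.

Compound 4 changes the atom attached to the aromatic carbon, the chain and its terminal group together, so the compounds shown leave open which of these parts carries the step. Also open, as far as these compounds go, is whether a carboxylic acid on the same oxygen-linked chain, or a saturated propanamide chain on the aromatic carbon, would stay level with compound 1 at 102% or fall towards compound 4 at 11% in this assay.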